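The source may hold more compounds than are shown below. What is called first, only, known or untested is meant among the compounds shown, and "the series" means these compounds.

Measured so far in a functional assay on SW480 cells (Homo sapiens) for cytotoxicity, read by MTT assay, with a stated time of 24 h; a higher number here means a weaker inhibitor, a lower number a stronger inhibitor:
Compound 1, `C=CC1=C(C(=O)NCc2ccc(C)cc2)C(c2ccc(F)cc2)OC1`, gives > 100000 nM, which is a limit of the assay and not a number.
Compound 2, `C=CC1=C(C(=O)NCc2ccccc2F)C(c2ccc(F)cc2)OC1`, gives > 100000 nM, likewise a limit.
Compound 3, `C=CC1=C(C(=O)NCc2ccc(C)cc2)C(c2ccc(OC)cc2)OC1`, gives 31700 nM.

The change between the first two is 2-fluorophenyl in place of 4-methylphenyl on a saturated chain carbon bound to an amide-type nitrogen, and its step is a step that the two limits leave unreadable from compound 1 to compound 2; the limit of > 100000 nM in this assay, at which 2 of the 3 values shown sit, leaves that pair silent on size. The two cores differ by methoxy in place of fluoro on an aromatic carbon, with a step of an at least 3.1-fold lower number from compound 1 to compound 3 (0.49 log units; beyond the scatter). Compound 4, `C=CC1=C(C(=O)NCc2ccccc2F)C(c2ccc(OC)cc2)OC1`, puts onto the core of compound 3 the same change, (2-fluorophenyl in place of 4-methylphenyl on a saturated chain carbon bound to an amide-type nitrogen), at the same place. For the measured compounds named here, with the earlier instance of this change unreadable, the step is expected to stay near flat, a 1.3-fold higher number from compound 3 to compound 4 (0.10 log units; within the scatter), resting on compound 3 at 31700 nM as the only number in hand. In this assay compound 4 is therefore estimated at 40000 nM, within 15000 nM to 110000 nM.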

Compound 4, half-maximal inhibitory concentration: > 100000 nM
Compound 4: a limit, no number; the forecaster's own chance of this, stated with the estimate: 35%; middle value at least 2.5-fold (0.39 log units) from the limit.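

In this assay, 2-fluorobenzyl in place of 4-methylbenzyl on the methoxy core gives an at least 3.1-fold higher number from compound 3 to compound 4 (0.49 log units; beyond the scatter), so the change costs activity on this core. Compound 4 gives > 100000 nM, which is a limit of the assay and not a number. Whether the size of this step carries from one core to another is not shown, since neither the same change on the core of compound 1 nor the methoxy-for-fluoro pair of compound 2 and compound 4 can be read, because both members of each pair sit at the same limit: the limit of > 100000 nM in this assay, at which 3 of the 4 values shown sit.

Still open, on these data alone, is how an amine or a carboxylic acid on a longer chain, in place of 4-methylbenzyl, would read on the core of compound 3. Also open, as far as these compounds go, is whether any compound on the fluoro core gives a number at all.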